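This account rests on a few compounds, and the source may have more. Where it says the series, first, only, none or still open, it means among the compounds named here.

Compound 1, `C=C1C[C@]23C[C@@]1(O)CC[C@H]2c1ccc(OS(=O)(=O)c2ccc(C)cc2)c(C)c1[C@@H]3Cn1cc(-c2ccc(Cl)cc2)nn1`: in a functional assay on SW480 cells (Homo sapiens) for cytotoxicity, read by MTT assay, with a stated time of 4 days (on this read-out higher numbers stand for weaker inhibition and lower numbers for stronger inhibition), compound 1 gives > 20000 nM
Compound 2, `C=C1C[C@]23C[C@@]1(O)CC[C@H]2c1ccc(OS(=O)(=O)c2ccc(C)cc2)c(C)c1[C@@H]3Cn1cc(-c2ccc(C)cc2)nn1`: in this assay compound 2 gives > 20000 nM
Compound 3, `C=C1C(=O)[C@]23C[C@@]1(O)CC[C@H]2c1ccc(O)c(C)c1[C@@H]3Cn1cc(-c2ccc(Cl)cc2)nn1`: in this assay compound 3 gives 280 nM.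

For compound 1 the value is a limit of the assay, not a number. For compound 2 the value is likewise a limit, (the limit of > 20000 nM in this assay, at which 2 of the 3 values shown sit). Compound 3 is the only one of the three with a number. Compound 1 and compound 2 share a core; compound 3 has another core, and the difference between the two cores is not broken down here. The change from compound 1 to compound 2, (methyl in place of chloro on an aromatic carbon), gives a step that the two limits leave unreadable from compound 1 to compound 2. Compound 4, `C=C1C(=O)[C@]23C[C@@]1(O)CC[C@H]2c1ccc(O)c(C)c1[C@@H]3Cn1cc(-c2ccc(C)cc2)nn1`, has not yet been measured in this assay. It differs from compound 3 by the same change, (methyl in place of chloro on an aromatic carbon), at the same place. Because a step that the two limits leave unreadable from compound 1 to compound 2 cannot be read, the earlier step offers no size to lean on, and only a small step is expected: a 1.3-fold higher number from compound 3 to compound 4 (0.10 log units; within the scatter). Compound 4 is expected near 350 nM, between 120 nM and 1100 nM.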

Compound 4, half-maximal inhibitory concentration: 330 nM
The estimate for compound 4 lay 1.1-fold (0.03 log units) above the measured number, within the range that was stated.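

In this assay, methyl in place of chloro on the core of compound 3 gives a 1.2-fold higher number from compound 3 to compound 4 (0.07 log units; within the scatter), so on this core the 4-chlorophenyl and 4-methylphenyl compounds cannot be told apart. On the core of compound 1 the same change cannot be read, since compound 1 and compound 2 each give a limit of the assay and not a number: the limit of > 20000 nM in this assay, at which 2 of the 4 values shown sit. The change therefore has a readable size on one core only, and these results do not show whether that size carries over from one core to the other.

All four compounds carry chloro or methyl at this place on the ring. From the compounds shown here alone, whether an amine or a carboxylic acid there, on the core of compound 3, would move the number beyond the scatter remains open.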